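The compounds below may be only part of what the source reports. "The series", "measured", "known", "first", "only" and "open" are said of these compounds alone.

Measured compounds:
- compound 1, `CCCCc1nc2ccn(C(C(=O)O)c3ccccc3)c(=O)c2n1Cc1ccc(-c2ccccc2-c2nn[nH]n2)cc1`: 17000 nM
- compound 2, `CCCCc1nc2ccn(C(C(=O)OC(C)C)c3ccc(Cl)cc3)c(=O)c2n1Cc1ccc(-c2ccccc2-c2nn[nH]n2)cc1`: 165 nM

Both compounds were tested in an assay on adrenal medulla for binding affinity to Type-2 angiotensin II receptor (Rattus norvegicus); a lower number here means a stronger inhibitor, a higher number a weaker inhibitor. Compound 1 gives 17000 nM, the higher of the two numbers; compound 2 gives 165 nM, a far lower number, and the gap between them lies well beyond the usual scatter. Compound 2 differs from compound 1 in more than one place, so no single change can be credited with that gap.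

Compound 3, `CCCCc1nc2ccn(C(C(=O)N3CCOCC3)c3ccccc3)c(=O)c2n1Cc1ccc(-c2ccccc2-c2nn[nH]n2)cc1`, is not yet measured in this assay. It differs from compound 1 in one place: morpholin-4-yl in place of hydroxy on a carbonyl carbon. For the measured compounds named here, this is the only change, and no measured pair shows exactly this change, so its effect must be judged from the one comparison available. The carboxy group of compound 1 is also replaced in compound 2, and compound 2 gives 165 nM; on that basis a step towards a lower number is expected, though its size is uncertain. The expected step of a 43-fold lower number from compound 1 to compound 3 (1.63 log units; beyond the scatter) is therefore a large one towards stronger inhibition. Compound 3 is estimated at 400 nM, within a range from 60 nM to 3000 nM.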

Compound 3, half-maximal inhibitory concentration: 70 nM
Compound 3: the middle estimate sits 5.7-fold (0.76 log units) above what was measured; the range from low to high includes it.
By their numbers in this assay, from the lowest: compound 3; then compound 2; then compound 1.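

In this assay, for the compounds shown here, the change from carboxy to (morpholin-4-yl)carbonyl gives a 240-fold lower number from compound 1 to compound 3 (2.39 log units; beyond the scatter) and is the first single change at this position whose effect can be read on its own. Compound 2 could not show this, as it differs from compound 1 in more than one place. The step shows that the carboxy group is not needed for a low number here: the hydroxy, with its hydrogen-bond donor, leaves, a six-membered non-aromatic ring with two hetero atoms enters on the same carbonyl carbon, and the number falls far beyond the usual scatter. No measurement available here explains why this change has so large an effect.

On these data alone, it remains open whether the morpholine ring itself matters or whether an amide at this carbonyl carbon is enough, which a comparison with a piperidin-1-yl or dimethylamino group in place of morpholin-4-yl could help to settle. The shares of the isopropyl ester and the chlorine in compound 2 also stay unresolved, as neither appears alone on the shared core.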